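Swapping an amide for a phenylpropyl amine on the shared core

The source may hold more compounds than are shown below. What is called first, only, known or untested is meant among the compounds shown, and "the series" means these compounds.

The series turns on a shared aminopyrimidine-like core in which two aryl groups sit on the ring and the exocyclic nitrogen carries a variable substituent. In an assay on CHO cells for displacement of a labelled ligand from adenosine receptor A1 (Homo sapiens), read by scintillation counting, with a stated time of 1 h, tested at 1 uM (a lower number here means less inhibition, a higher number more inhibition at the concentration tested (going by the name of the read-out)), compound 1 `Nc1ncc(-c2ccc(O)c(Cl)c2)c(-c2ccccc2)n1` reaches only the limit of the assay, at > 80%. Compound 2 `Nc1ncc(-c2ccccc2)c(-c2ccco2)n1` gives 26% in this assay. Compound 3 `O=C(Nc1ncc(-c2cccc(Cl)c2)c(-c2ccccc2)n1)C1CCCC1` gives 47% in this assay, the higher of the two numbers recorded, and its gap to compound 2 lies beyond the usual scatter. The value of compound 1 is a limit of the assay. Among the compounds with values here, no single-change step between measured compounds exists, so the effect of altering the nitrogen substituent is untested. Compound 4 `Clc1cccc(-c2cnc(NCCCc3ccccc3)nc2-c2ccccc2)c1` differs from compound 3 by 3-phenylpropyl in place of cyclopentylcarbonyl on a nitrogen on an aromatic ring. Compound 4 is expected to show a small rise in this assay, with a number 8 percentage points higher from compound 3 to compound 4 (within the scatter) as the estimated step, though a flat outcome within the scatter is also plausible. The estimated value for compound 4 in this assay is 55%, within a range from 25% to 85%.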

Compound 4, a percentage reported as inhibition, at one concentration (the size of the read-out at that concentration, not a potency): 33%
Compound 4: the middle estimate sits 22 percentage points above what was measured, within the range that was stated.
By their numbers in this assay, from the lowest: compounds 2 and 4 (each within the scatter of the next); then compound 3. At a limit, above all of these: compound 1.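

The substituent on the nitrogen now has its first direct reading: with 3-phenylpropyl in place of cyclopentylcarbonyl, this assay shows a number 14 percentage points lower from compound 3 to compound 4 (beyond the scatter), so this position responds to the change and the swap brings no gain. The swap alters several things at once, removing the carbonyl and the five-membered ring and bringing in a six-membered aromatic ring on a chain, and this single step cannot separate them. Nothing in the data shown bears on a cause for the drop.

On these data alone, it remains open whether a plain cyclopentyl group on the nitrogen, without the carbonyl, or a phenylacetyl amide, which keeps the carbonyl and carries an aromatic ring, would stand nearer compound 3 or compound 4. Also open, as far as these compounds go, is how a benzyl group or a longer phenylalkyl chain would compare with 3-phenylpropyl at this nitrogen.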